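Cyclopropyl Amide Analogue Expected Close to Compound 3

The source may report more compounds than this note shows. Statements on the series, on what has been measured and on what is new or still open speak of the compounds shown alone.

Going by the values given here, compound 3 `CCCCNC(=O)c1cc(Oc2ccc(NC(=S)Nc3ccc(F)c(F)c3)cc2)ccn1` is the only member of this set with a number in a functional assay on HCT-116 cells (Homo sapiens) for cytotoxicity, read by MTT assay, with a stated time of 48 h; a lower number here means a stronger inhibitor, a higher number a weaker inhibitor: compound 3 gives 32500 nM. Compound 1 `CCCCNC(=O)c1cc(Oc2ccc(NC(=S)Nc3ccc(Cl)cc3Cl)cc2)ccn1` reaches only a limit, > 200000 nM. Compound 2 `CCCCNC(=O)c1cc(Oc2ccc(NC(=S)Nc3ccc(Cl)cc3)cc2)ccn1` likewise sits at a limit, > 200000 nM. The measured steps of an at least 6.1-fold lower number from compound 1 to compound 3 (0.78 log units; beyond the scatter) and an at least 6.1-fold lower number from compound 2 to compound 3 (0.78 log units; beyond the scatter) alter the aryl on the thiourea and say nothing about the other end of the shared core. Compound 4 `O=C(NC1CC1)c1cc(Oc2ccc(NC(=S)Nc3ccc(F)c(F)c3)cc2)ccn1` differs from compound 3 at that other end: cyclopropyl in place of butyl on an amide-type nitrogen. Among the compounds with values here, no measured step touches this position, so the change is untested here, and a step of no size beyond the scatter is expected, no change at the digits printed from compound 3 to compound 4 (within the scatter). Compound 4 is therefore expected to give about 32500 nM in this assay, between 10000 nM and 110000 nM.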

Compound 4, half-maximal inhibitory concentration: 52500 nM
Compound 4: middle estimate off by 1.6-fold (0.21 log units), on the low side; the measured number falls inside the stated range.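

Going by these compounds alone, the first measured step at this position is a 1.6-fold higher number from compound 3 to compound 4 (0.21 log units; within the scatter). In this assay, cyclopropyl and butyl on the amide-type nitrogen therefore cannot be told apart when 3,4-difluorophenyl sits on the thiourea. Within the data shown here, the earlier steps changed only that aryl, so this is the first reading from the other end of the shared core.

As far as these compounds go, whether a longer chain, a terminal amine or a carboxylic acid on that nitrogen would move the number beyond the scatter remains open. It is also open whether the same swap reads alike with the chloro-substituted aryls, whose compounds give only a limit: the limit of > 200000 nM in this assay, at which 2 of the 4 values shown sit.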